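Half-life notes: from compound 3 to compound 4

The source may report more compounds than this note shows. Statements on the series, on what has been measured and on what is new or still open speak of the compounds shown alone.

Within the data shown here, in an ADME assay on microsomes from liver (Rattus norvegicus, strain Sprague-Dawley) for metabolic stability, read by HPLC, using NADPH, with stated times of 5 min and 60 min, tested at 10 uM (on this read-out lower numbers stand for a shorter-lived compound and higher numbers for a longer-lived compound), three compounds have numbers so far. Compound 1 (`CCS(=O)(=O)Nc1ccc(CNC(=O)c2ccc(C(C)(C)C)cc2)c(Cl)c1`) gives 0.783 h in this read-out. Compound 2 (`CC(C)(C)c1ccc(C(=O)NCc2c(Cl)cc(NS(C)(=O)=O)cc2Cl)cc1`) gives 1.37 h in the same read-out. Compound 3 (`CS(=O)(=O)Nc1ccc(CNC(=O)c2ccc(C34CC(C3)C4)cc2)c(Cl)c1`) gives 1.35 h and stands within the scatter of both others, so these three values carry no order.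

Compound 4 (`CS(=O)(=O)Nc1ccc(CNC(=O)c2ccc(OC(F)(F)F)cc2)c(Cl)c1`) has not been measured yet. Its structural change from compound 3 is a group of 5 heavy atoms (1 carbon, 1 oxygen, 3 fluorine; no ring) in place of a group of 5 heavy atoms (5 carbon; 2 four-membered non-aromatic rings of carbon only), on an aromatic carbon and it lies para to a large group. The trifluoromethoxy group has not been measured in any other compound of this set. Among the measured compounds shown here, no two measured compounds differ in one place only, so no direct step is available as a guide.

The expectation in this assay is therefore no step beyond the scatter, with no firm direction. It rests on compound 3 at 1.35 h as the starting point, and on the three measured values staying within the scatter of each other despite their structural differences. The estimate means a step of a 1.1-fold higher number from compound 3 to compound 4 (0.05 log units; within the scatter) and that expected step stays inside the scatter. For compound 4 the estimated value is 1.5 h with an expected range from 0.7 h to 3.2 h in this read-out.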

Compound 4, half-life: 2.47 h
Estimate against measurement, compound 4: 1.6-fold (0.22 log units) below, within the range that was stated.
By their numbers in this assay, from the lowest: compounds 1, 3, 2 and 4 (each within the scatter of the next, the first and the last beyond it).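

Among these compounds, compound 3 and compound 4 give the first step between compounds that differ in one place: in this assay, trifluoromethoxy in place of the carbon-only group with two four-membered rings, on an aromatic carbon para to a large group, gives a 1.8-fold higher number from compound 3 to compound 4 (0.26 log units; within the scatter) and so shows no change that can be told from the scatter. Among the compounds shown here, at this place, a ring-free group with oxygen and fluorine and a carbon-only group with two rings, each of the same heavy-atom count, therefore cannot be told apart on half-life, and the earlier compounds, which offered no single-place comparison, could not show this. No measurement at hand bears on what lies behind this result.

Open, from the compounds shown here alone, is whether any group at this place moves the half-life beyond the scatter, for instance an amine, a carboxylic acid, a methoxy group or a longer chain. Also open, going by these compounds, is whether trifluoromethoxy gives a step of similar size on the core of compound 1 or on the core of compound 2, as a single step of this kind says nothing about other cores.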